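Paw edema series: methoxy in place of bromo

The source may report more compounds than this note shows. Statements on the series, on what has been measured and on what is new or still open speak of the compounds shown alone.

Measured in a functional assay on the whole organism (strain albino) for inhibition, with Rattus norvegicus as the target, read by paw edema, with a stated time of 60 min, at a dose of 100 mg/kg by the oral route; on this read-out higher numbers stand for more inhibition at the one dose given (going by the name of the read-out) and lower numbers for less inhibition:
Compound 1 `Clc1ccccc1NCc1nc2ccc(Br)cc2[nH]1` gives 20%.
Compound 2 `Brc1ccc(NCc2nc3ccc(Br)cc3[nH]2)cc1` gives 20%.
Compound 3 `Clc1cccc(NCc2nc3ccc(Br)cc3[nH]2)c1` gives 26.6%.

Compound 2 stands level with compound 1 at the digits reported, the two together the lowest of the three numbers; compound 3 is the furthest from compound 2, a number only slightly higher and within the scatter, so no order among the three is established. Compound 4 `COc1ccc(NCc2nc3ccc(Br)cc3[nH]2)cc1` is not yet measured. It differs from compound 2 by methoxy in place of bromo on an aromatic carbon. Going by the values given here, no measured pair shows a step of this kind, so there is nothing to anchor a direction, and the three measured compounds all sit within the scatter of one another. The expected step of a number 2 percentage points higher from compound 2 to compound 4 (within the scatter) is therefore none beyond the scatter. Compound 4 is estimated at 22%, with a range of 10% to 35% in this assay.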

Compound 4, a percentage reported as inhibition, in the whole organism at one dose (the size of the read-out at that dose, not a potency): 13.3%
For compound 4 the middle estimate is 8.7 percentage points above the measured one; low and high end bracket the measured number.
By their numbers in this assay, from the lowest: compounds 4, 1, 2 and 3 (each within the scatter of the next, the first and the last beyond it).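

In this assay, methoxy in place of bromo on an aromatic carbon, para to a large group, gives a number 6.7 percentage points lower from compound 2 to compound 4 (within the scatter). This first step of its kind at this position shows that exchanging bromo for methoxy, which adds one hydrogen-bond acceptor, does not shift the read-out beyond the usual scatter. No measured evidence bears on the reason for this result.

From the compounds shown here alone, whether an amine or a carboxylic acid at this position would give a step beyond the scatter remains open. Also open, going by these compounds, is whether methoxy would give the same result on a compound with a different substituent on the core.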